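Fluorine Placement on a Benzyl Group Tried Once More

The source may report more compounds than this note shows. Statements on the series, on what has been measured and on what is new or still open speak of the compounds shown alone.

Measured so far:
Compound 1, `CC1(C)c2[nH]nc(NC(=O)c3ccccc3)c2CN1Cc1cc(F)cc(F)c1`: 190 nM
Compound 2, `CC1(C)c2[nH]nc(NC(=O)c3ccccc3)c2CN1Cc1cccc(F)c1F`: 200 nM
Compound 3, `CN1CCN(c2ccc(C(=O)Nc3n[nH]c4c3CN(Cc3cccc(F)c3F)C4(C)C)cc2)CC1`: 17 nM

All three numbers come from an assay on Sf21 cells for inhibition of high affinity nerve growth factor receptor (Homo sapiens), read by HTRF, with a stated time of 30 min, in the presence of a further agent that is not named here; a lower number here means a stronger inhibitor, a higher number a weaker inhibitor. In this assay compound 1 gives 190 nM and compound 2 gives 200 nM; the pair differ by 3,5-difluorophenyl in place of 2,3-difluorophenyl on a saturated chain carbon bound to an amine nitrogen in a ring, and the step of a 1.1-fold lower number from compound 2 to compound 1 (0.02 log units; within the scatter) lies within the scatter, so the two values are treated as alike. Compound 3 gives 17 nM, the lowest of the three numbers, and it differs from compound 2 by 4-methylpiperazin-1-yl in place of hydrogen on an aromatic carbon, the step being a 12-fold lower number from compound 2 to compound 3 (1.07 log units; beyond the scatter).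

Compound 4, `CN1CCN(c2ccc(C(=O)Nc3n[nH]c4c3CN(Cc3cc(F)cc(F)c3)C4(C)C)cc2)CC1`, has not yet been measured. It differs from compound 3 by 3,5-difluorophenyl in place of 2,3-difluorophenyl on a saturated chain carbon bound to an amine nitrogen in a ring. This is the same change that separates compound 2 from compound 1, and it is the second time it occurs among these four compounds. The cores of compound 3 and compound 4 differ from those of compound 1 and compound 2 only in the way given by 4-methylpiperazin-1-yl in place of hydrogen on an aromatic carbon.

The expectation for compound 4 rests on a single earlier example: the change gave a 1.1-fold lower number from compound 2 to compound 1 (0.02 log units; within the scatter) between compound 2 and compound 1, a step within the scatter. Compound 4 is therefore expected to sit near compound 3, with a step of about a 1.1-fold lower number from compound 3 to compound 4 (0.03 log units; within the scatter), since compound 3 gives 17 nM. Whether the change behaves the same on the core that carries the 4-methylpiperazin-1-yl group cannot be checked from the measured compounds; the estimate is accordingly given a wide range. Compound 4 is estimated at 16 nM, between 7 nM and 40 nM.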

Compound 4, half-maximal inhibitory concentration: 17 nM
For compound 4 the middle estimate is 1.1-fold (0.03 log units) below the measured one, within the range that was stated.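

In this assay, moving the fluorines from 2,3-difluorobenzyl to 3,5-difluorobenzyl on the core that carries the 4-methylpiperazin-1-yl group gave no change at the digits printed from compound 3 to compound 4 (within the scatter), and this step agrees with the same change on the core without that group: the same change on two cores in this assay, a 1.1-fold lower number (0.02 log units; within the scatter) from compound 2 to compound 1 and no change at the digits printed (within the scatter) from compound 3 to compound 4, 1.1-fold (0.02 log units) apart, within the scatter of two such steps The 4-methylpiperazin-1-yl group also kept its size across the two benzyl groups, giving an 11-fold lower number from compound 1 to compound 4 (1.05 log units; beyond the scatter), which agrees with its earlier step on the 2,3-difluorobenzyl compounds: the same change on two cores in this assay, a 12-fold lower number (1.07 log units; beyond the scatter) from compound 2 to compound 3 and an 11-fold lower number (1.05 log units; beyond the scatter) from compound 1 to compound 4, 1.1-fold (0.02 log units) apart, within the scatter of two such steps Across these four compounds, each change therefore reads the same whichever form the other part takes, but this rests on just two fluorine patterns and one added group in one assay, and it does not show that the agreement extends to other groups or other cores.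

The compounds shown leave open whether a benzyl group bearing a single fluorine, a chlorine or a methoxy group would match these difluorobenzyl compounds. They also leave open whether another amine in place of 4-methylpiperazin-1-yl, such as morpholine or a dimethylamino group, would give a step of similar size and carry across the benzyl groups in the same way.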